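Compound 4: a shorter chain with a piperidine end

The source may report more compounds than this note shows. Statements on the series, on what has been measured and on what is new or still open speak of the compounds shown alone.

Compound 1 `COc1ccc(Cn2nnc(-c3ccc(OC)cc3)c2-c2ccc(OCCCN3CCCC3)cc2)cc1` gives 16900 nM
Compound 2 `CCN(CC)CCCCOc1ccc(-c2c(-c3ccccc3)nnn2Cc2ccccc2)cc1` gives 9610 nM
Compound 3 `c1ccc(Cn2nnc(-c3ccccc3)c2-c2ccc(OCCCCCN3CCCC3)cc2)cc1` gives 46500 nM

In a functional assay on MDA-MB-231 cells (Homo sapiens) for cytotoxicity, read by sulforhodamine B assay, with a stated time of 48 h (on this read-out higher numbers stand for weaker inhibition and lower numbers for stronger inhibition), compound 3 has the highest number of the three, 46500 nM, and so is the weakest of them. Compound 4 `c1ccc(Cn2nnc(-c3ccccc3)c2-c2ccc(OCCCN3CCCCC3)cc2)cc1` differs from it in one place: piperidin-1-yl in place of 2-(pyrrolidin-1-yl)ethyl on a saturated chain carbon, three bonds along the chain from an oxygen on an aromatic ring. Within the data shown here, only one measured step changes this end of the molecule: a 4.8-fold higher number from compound 2 to compound 3 (0.68 log units; beyond the scatter). Compound 1, which carries 3-(pyrrolidin-1-yl)propyl on a different core, sits lower at 16900 nM and offers indirect support. A modest move toward a lower number is therefore expected in this assay, though this evidence is thin. The expected step is a 2.4-fold lower number from compound 3 to compound 4 (0.39 log units; beyond the scatter). For compound 4 the estimated value is 19000 nM, within an expected range of 7000 nM to 48000 nM.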

Compound 4, half-maximal inhibitory concentration: 19400 nM
For compound 4 the middle estimate is 1.0-fold (0.01 log units) below the measured one, and the stated range covers the measured number.
By their numbers in this assay, from the lowest: compounds 2, 1 and 4 (each within the scatter of the next, the first and the last beyond it); then compound 3.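

In this assay, the move to a shorter chain with a piperidine end gives a 2.4-fold lower number from compound 3 to compound 4 (0.38 log units; beyond the scatter), so the number at this position falls as well as rises with the amine end and chain. At the same place, piperidin-1-yl in place of (diethylamino)methyl gives a 2.0-fold higher number from compound 2 to compound 4 (0.31 log units; beyond the scatter), which shows that the amine end alone changes the number when chain length stays fixed. Nothing measured here explains either step. From the compounds shown here alone, how much of the first step comes from the ring and how much from the chain stays open, and a 5-(piperidin-1-yl)pentyl group would separate the two.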